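From 3-fluorophenyl to 3,4-dimethylphenyl on the shared core

The compounds below may be only part of what the source reports. "The series", "measured", "known", "first", "only" and "open" are said of these compounds alone.

In a functional assay on KB cells (Homo sapiens) for antiproliferative activity, read by sulforhodamine B assay, with a stated time of 3 days (a higher number here means that more compound is needed for the effect, a lower number that less compound is needed), compound 1 `CCC1=C(O)c2c(oc(-c3ccc(OC)cc3)cc2=O)C(CC)(CC)C1=O` gives 17.7 uM as a measured number. Compound 2 `CCC1=C(O)c2c(oc(-c3ccc(CBr)cc3)cc2=O)C(CC)(CC)C1=O` gives only a limit of the assay (> 46.5 uM). Compound 3 `CCC1=C(O)c2c(oc(-c3cccc(F)c3)cc2=O)C(CC)(CC)C1=O` likewise stands at a limit (> 56.2 uM) and has no number of its own. Compound 4 `CCC1=C(O)c2c(oc(-c3ccc(C)c(C)c3)cc2=O)C(CC)(CC)C1=O` carries 3,4-dimethylphenyl in place of 3-fluorophenyl on an aromatic carbon. The closest guide is an at least 3.1-fold higher number from compound 1 to compound 3 (0.50 log units; beyond the scatter) and, alongside it, an at least 2.6-fold higher number from compound 1 to compound 2 (0.41 log units; beyond the scatter) while a step that the two limits leave unreadable from compound 2 to compound 3 stays unreadable. Resting on compound 1 at 17.7 uM as the only measured number, a modest step toward a lower number is expected in this assay though none beyond the scatter remains possible. Compound 4 is expected at 35 uM (estimated range 12 uM to 60 uM). This estimate means an at least 1.6-fold lower number from compound 3 to compound 4 (0.20 log units; that floor lies within the scatter) as the expected step.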

Compound 4, concentration for half-maximal effect: 35.5 uM
Compound 4: middle estimate off by 1.0-fold (0.01 log units), on the low side; the measured number falls inside the stated range.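

For the compounds shown here, compound 4 gives a measured number in this assay, so 4-methoxyphenyl is no longer the only group at this position to give one, and the two read alike: a 2.0-fold higher number from compound 1 to compound 4 (0.30 log units; within the scatter). The other two steps, an at least 1.5-fold lower number from compound 3 to compound 4 (0.19 log units; that floor lies within the scatter) and an at least 1.3-fold lower number from compound 2 to compound 4 (0.11 log units; that floor lies within the scatter), have floors within the scatter, so neither establishes a real difference. Compound 3 stands only at a limit of the assay: the limit of > 56.2 uM in this assay, at which 1 of the 4 values shown sits.

Still open, from the compounds shown here alone, is how an amine or a carboxylic acid on this phenyl ring would read. Also open, going by these compounds, is how a longer chain in place of either methyl group would read.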